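Cyclohexylmethyl amide in a colon-cell cytotoxicity screen

A few compounds are considered here, and "the series" means these few. Any claim that something is new, unique, unknown or untested is made for them only; others in the source may bear on it.

Measured so far in an ADME assay on NCM460 cells (Homo sapiens) for cytotoxicity, read by MTT assay, with a stated time of 72 h; a lower number here means a stronger inhibitor, a higher number a weaker inhibitor:
compound 1 `O=C(Nc1cccc(F)c1)c1cccc(/C=C2\CC(=O)N(c3ccccc3)C2=O)c1`, a limit of the assay, > 100000 nM
compound 2 `O=C(c1cccc(/C=C2\CC(=O)N(c3ccccc3)C2=O)c1)N1CCCC1`, a limit of the assay, > 100000 nM
compound 3 `COc1ccc(OC)c(NC(=O)c2cccc(/C=C3\CC(=O)N(c4ccccc4)C3=O)c2)c1`, a limit of the assay, > 100000 nM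

Compound 3 stands at the limit of this assay, > 100000 nM, and so gives no number of its own. All three measured compounds sit at that same limit (the limit of > 100000 nM in this assay, at which 3 of the 3 values shown sit), so the steps leading to compound 3 cannot be sized: a step that the two limits leave unreadable from compound 1 to compound 3 and a step that the two limits leave unreadable from compound 2 to compound 3 are both unreadable, as is a step that the two limits leave unreadable from compound 1 to compound 2 between the other two.

Compound 4 `O=C(NCC1CCCCC1)c1cccc(/C=C2\CC(=O)N(c3ccccc3)C2=O)c1` differs from compound 3 by cyclohexylmethyl in place of 2,5-dimethoxyphenyl on an amide-type nitrogen. Within the data shown here, no measured step bears readably on this change, and none of the three measured compounds gives a number in this assay. The expectation for compound 4 is therefore a step no larger than the unreadable ones, a step that the limit leaves unreadable from compound 3 to compound 4, most likely ending again at the limit. Compound 4 is estimated at 150000 nM, with an expected range from 40000 nM to 600000 nM.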

Compound 4, half-maximal inhibitory concentration: > 100000 nM
Compound 4 gave a limit, no number; the forecaster's own chance of this, stated with the estimate: 85%; the middle value lies beyond the limit too.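

Compound 4 gave only a limit, so no step from compound 1, compound 2 or compound 3 to compound 4 can be read: the limit of > 100000 nM in this assay, at which 4 of the 4 values shown sit.

The compounds shown leave open whether any amide on the shared core gives a measurable value in this assay.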